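Dropping One Trifluoromethyl from a Weak Sulfonyl Amide

The source may report more compounds than this note shows. Statements on the series, on what has been measured and on what is new or still open speak of the compounds shown alone.

Three amides sharing one core have been tested in a functional assay on LNCaP cells (Homo sapiens) for antiproliferative activity, read by fluorescence and propidium iodide staining, with a stated time of 96 h; on this read-out lower numbers stand for stronger inhibition and higher numbers for weaker inhibition. Compound 1 `O=C(Nc1cc(C(F)(F)F)ccc1C(F)(F)F)c1ccc(Sc2ccc(O)cc2)cc1` gives 11400 nM. Compound 2 `O=C(Nc1cc(C(F)(F)F)cc(C(F)(F)F)c1)c1ccc(S(=O)(=O)c2ccc(O)cc2)cc1`, which also carries two trifluoromethyl groups and a sulfonyl link, gives 8410 nM. Compound 3 `O=C(Nc1cc(C(F)(F)F)ccc1C(F)(F)F)c1ccc(S(=O)(=O)c2ccc(O)cc2)cc1` gives 23200 nM, the highest of the three numbers, so it is the weakest inhibitor among them. The only single-point step among these three, a 2.0-fold higher number from compound 1 to compound 3 (0.31 log units; beyond the scatter), concerns the link between the rings and not the substituents on the amide-bearing ring.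

Compound 4 `O=C(Nc1cccc(C(F)(F)F)c1)c1ccc(S(=O)(=O)c2ccc(O)cc2)cc1` differs from compound 3 by hydrogen in place of trifluoromethyl on an aromatic carbon. Going by the values given here, no measured step describes such a removal, so the expectation rests on the general picture: all three numbers sit within a narrow, weak band, and a change of this kind is expected to move the number little. The step from compound 3 to compound 4 is estimated as a 1.5-fold lower number from compound 3 to compound 4 (0.19 log units; within the scatter). Compound 4 is therefore expected to give 15000 nM, with a range from 5000 nM to 45000 nM.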

Compound 4, half-maximal inhibitory concentration: 10200 nM
Compound 4: the middle estimate sits 1.5-fold (0.17 log units) above what was measured, within the range that was stated.
By their numbers in this assay, from the lowest: compounds 2, 4 and 1 (each within the scatter of the next); then compound 3.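

In this assay, swapping the trifluoromethyl group that sits ortho to a large group and para to a trifluoromethyl group for hydrogen gives a 2.3-fold lower number from compound 3 to compound 4 (0.36 log units; beyond the scatter) and this modest step lies beyond the scatter, so on this sulfonyl amide that site does not tolerate the larger group as well as it tolerates hydrogen. The same kind of swap starting from the other arrangement of two trifluoromethyl groups gives a 1.2-fold higher number from compound 2 to compound 4 (0.08 log units; within the scatter) and this step stays within the scatter, so the effect of losing a trifluoromethyl group depends on where it stood. No measurement available here explains why these two swaps differ.

As far as these compounds go, whether a fluorine atom, a methoxy group or an amine at this position would match hydrogen remains open. So does whether the same swap would behave alike on the sulfanyl link of compound 1.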